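Methoxycarbonyl for bromo on the benzamide ring: compound 3

A few compounds are considered here, and "the series" means these few. Any claim that something is new, unique, unknown or untested is made for them only; others in the source may bear on it.

Measured so far in an assay on isolated protein for inhibition of Rho-associated protein kinase 1 (Homo sapiens), read by scintillation counting, radiometric assay and 33P incorporation, with a stated time of 40 min, in the presence of a further agent that is not named here; a lower number here means a stronger inhibitor, a higher number a weaker inhibitor:
Compound 1 `CC(C)(C)c1ccc(C(=O)Nc2cccc(NC(=O)COc3ccc4c(=O)ccoc4c3)c2)cc1` gives 165 nM.
Compound 2 `O=C(COc1ccc2c(=O)ccoc2c1)Nc1cccc(NC(=O)c2ccc(Br)cc2)c1` gives 303 nM.

Compound 2 stands at the highest of the two numbers. For the measured compounds named here, its only neighbour is compound 1, and the single step so far, a 1.8-fold higher number from compound 1 to compound 2 (0.26 log units; within the scatter), is within the scatter, so the two compounds are not separated by these measurements.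

Compound 3 `COC(=O)c1ccc(C(=O)Nc2cccc(NC(=O)COc3ccc4c(=O)ccoc4c3)c2)cc1` differs from compound 2 in one place: methoxycarbonyl in place of bromo on an aromatic carbon. Going by the values given here, no measured step exchanges bromo for methoxycarbonyl, and no measured compound carries an ester at this position. Among the compounds with values here, the only step that bears on the site at all is the tert-butyl to bromo exchange, which stayed within the scatter. On that basis no step beyond the scatter is expected for compound 3 in this assay, a 1.0-fold lower number from compound 2 to compound 3 (0.00 log units; within the scatter). The estimate for compound 3 is 300 nM, with a range from 110 nM to 850 nM.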

Compound 3, half-maximal inhibitory concentration: 72 nM
Estimate against measurement, compound 3: 4.2-fold (0.62 log units) above; the whole stated range lies above it.
By their numbers in this assay, from the lowest: compound 3; then compounds 1 and 2 (each within the scatter of the next).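

In this assay, this position now proves sensitive to the group it carries: methoxycarbonyl gives a 4.2-fold lower number from compound 2 to compound 3 (0.62 log units; beyond the scatter) and a 2.3-fold lower number from compound 1 to compound 3 (0.36 log units; beyond the scatter), whereas bromo and tert-butyl could not be separated. Both steps are modest, but they set compound 3 apart as the strongest inhibitor of the three, and methoxycarbonyl brings 2 hydrogen-bond acceptors where bromo brings none, although a single compound cannot tie the step to that count. Nothing available explains the step.

As far as these compounds go, whether the step depends on the intact methyl ester remains open, and a carboxylic acid, a primary amide or an ethyl ester at this position would bear on that. A nitrile or an acetyl group would show whether a smaller acceptor-bearing group gives a similar step.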